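Amide-nitrogen aryl swap in a paw-edema series

The compounds below may be only part of what the source reports. "The series", "measured", "known", "first", "only" and "open" are said of these compounds alone.

Two members of the shared core have been measured so far. Compound 1 `Nc1ccc(NC(=O)c2c(O)c3cccnc3n(-c3ccccc3)c2=O)cc1` gives -5.5% in a functional assay on the whole organism for inhibition, with Rattus norvegicus as the target, read by paw edema, at a dose of 100 mg/kg by the oral route; on this read-out higher numbers stand for more inhibition at the one dose given (going by the name of the read-out) and lower numbers for less inhibition. For the measured compounds named here, compound 2 `O=C(Nc1cccc([N+](=O)[O-])c1)c1c(O)c2cccnc2n(-c2ccccc2)c1=O` gives 5.7% in this assay, which places compound 2 higher of the two, the only step measured being a number 11.2 percentage points higher from compound 1 to compound 2 (beyond the scatter). Compound 3 `O=C(Nc1cnccn1)c1c(O)c2cccnc2n(-c2ccccc2)c1=O` has not yet been measured; it departs from compound 2 by pyrazin-2-yl in place of 3-nitrophenyl on an amide-type nitrogen. Going by the values given here, no measured step exchanges a carbocyclic aryl for a six-membered heteroaryl on that amide-type nitrogen, so the one step on record bears only loosely, as a sign that a change of the aryl substituent at this position has so far moved the read-out only modestly. Against that background the expectation for compound 3 is a step of a number 2.7 percentage points lower from compound 2 to compound 3 (within the scatter) relative to compound 2, that is, nothing clearly beyond the scatter in either direction. The estimate for compound 3 is therefore 3% in this assay, with a plausible range from -12% to 18%.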

Compound 3, a percentage reported as inhibition, in the whole organism at one dose (the size of the read-out at that dose, not a potency): 29.6%
Compound 3: the middle estimate sits 26.6 percentage points below what was measured, and the stated range ends below it.
By their numbers in this assay, from the lowest: compound 1; then compound 2; then compound 3.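

In this assay, for the compounds shown here, the amide-type nitrogen proves more sensitive than the one earlier step could show: pyrazin-2-yl in place of 3-nitrophenyl gives a number 23.9 percentage points higher from compound 2 to compound 3 (beyond the scatter), and pyrazin-2-yl in place of 4-aminophenyl gives a number 35.1 percentage points higher from compound 1 to compound 3 (beyond the scatter). The earlier step, a number 11.2 percentage points higher from compound 1 to compound 2 (beyond the scatter), exchanged one ring of carbon only for another, whereas these two steps bring in a six-membered aromatic ring with 2 hetero atoms, so the nature of the ring on this nitrogen now matters to the read-out, at least across these three compounds. Nothing at hand explains the step, and which feature of pyrazin-2-yl carries it stays unassigned.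

The compounds shown leave open whether the higher number belongs to the hetero atoms of the pyrazin-2-yl ring or to the absence of a substituted phenyl, a question that pyridin-2-yl or unsubstituted phenyl on the same nitrogen would help to separate. Also open, on these data alone, are how a non-aromatic group such as cyclohexyl would behave at this position and whether the order of the three compounds would hold at other doses.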